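The source may report more compounds than this note shows. Statements on the series, on what has been measured and on what is new or still open speak of the compounds shown alone.

Measured compounds:
compound 1 `Nc1ccccc1NC(=O)c1ccc(CSC(=S)N2CCN(c3ccc(Cl)cc3)CC2)cc1` gives 32.2%;
compound 2 `CC1CCN(C(=S)SCc2ccc(C(=O)Nc3ccccc3N)cc2)CC1` gives 32.7%;
compound 3 `Nc1ccccc1NC(=O)c1ccc(CSC(=S)N(Cc2ccccc2)Cc2ccccc2)cc1` gives 10.9%.

These three compounds were tested in a functional assay on A-375 cells (Homo sapiens) for antiproliferative activity, read by CCK-8 assay, with a stated time of 72 h, tested at 2 uM; a lower number here means a weaker effect, a higher number a stronger effect of the compound at the concentration tested. Compound 1 stands second highest of the three numbers. Its nearest neighbour is compound 2, whose value lies within the usual scatter of compound 1, so the two cannot be told apart. Compound 3 lies furthest away, and its lower value falls beyond the scatter, so compound 3 shows a weaker effect than compound 1.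

From compound 1 the account moves to compound 4 `Nc1ccccc1NC(=O)c1ccc(CSC(=S)N2CCN(Cc3cccnc3)CC2)cc1`, which has not yet been measured in this assay. The change is (pyridin-3-yl)methyl in place of 4-chlorophenyl on an amine nitrogen in a ring.

Within the data shown here, no step between measured compounds matches this change. Since compound 2 gives 32.7% with a quite different group on the ring nitrogen yet sits within the scatter of compound 1, the step of a number 4.2 percentage points lower from compound 1 to compound 4 (within the scatter) is expected to be none beyond the scatter, with a slight lean downward. Compound 4 is therefore estimated to give 28%, within a range from 12% to 44%.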

Compound 4, a percentage reported as inhibition, at one concentration (the size of the read-out at that concentration, not a potency): 31.5%
Beside the measured number, compound 4's estimate is 3.5 percentage points below it; measured number inside the range.
By their numbers in this assay, from the lowest: compound 3; then compounds 4, 1 and 2 (each within the scatter of the next).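

In this assay the step to (pyridin-3-yl)methyl in place of 4-chlorophenyl on the amine nitrogen in the ring is a number 0.7 percentage points lower from compound 1 to compound 4 (within the scatter) and shows no readable change. At this position, then, a chlorine-bearing carbon ring can give way to a ring with one hetero atom and one hydrogen-bond acceptor without any difference that this read-out can resolve. Nothing given here offers a reason for this.

On these data alone, a plain benzyl group on the same nitrogen would separate the ring nitrogen of compound 4 from the loss of the chlorine, and that question stays open. So does the outcome with a carboxylic acid or a longer chain ending in an amine at this place.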